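A Dimethylphenyl for a Chlorophenyl at the Ring Amine

The compounds below may be only part of what the source reports. "The series", "measured", "known", "first", "only" and "open" are said of these compounds alone.

Of the compounds shown here, three have so far been measured in an assay on HEK293 cells for inhibition of Voltage-dependent T-type calcium channel subunit alpha-1G (Homo sapiens), read by fluorescence, tested at 10 uM; on this read-out higher numbers stand for more inhibition at the one concentration tested (going by the name of the read-out) and lower numbers for less inhibition. Compound 1 `CCCc1nc(-c2ccccc2)c(CNCCN2CCN(c3ccccc3Cl)CC2)o1` gives 60.1% in this assay. Compound 2 `Cc1nc(-c2ccccc2)c(CNCCN2CCN(C(c3ccccc3)c3ccccc3)CC2)o1` gives 57.3% in this assay, and compound 3 `CCCc1nc(-c2ccccc2)c(CNCCCN2CCN(c3cccc(Cl)c3)CC2)o1` gives 65.9% in this assay. Compound 1 stands second highest of the three numbers; its nearest neighbour is compound 2, whose number is lower by a gap that lies within the scatter, and the furthest is compound 3, whose number is higher by a gap that also lies within the scatter. On these numbers the three compounds cannot be told apart.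

Compound 4 `CCCc1nc(-c2ccccc2)c(CNCCN2CCN(c3cccc(C)c3C)CC2)o1` has not yet been measured. It differs from compound 1 in one place: 2,3-dimethylphenyl in place of 2-chlorophenyl on an amine nitrogen in a ring

For the measured compounds named here, no two measured compounds differ in a single place, so no measured step points the way. The three measured compounds differ from one another in several places at once and still give numbers within the scatter of each other. The step from compound 1 to compound 4 is therefore expected to be small, a number 2.1 percentage points lower from compound 1 to compound 4 (within the scatter), and not beyond the scatter in either direction. Compound 4 is estimated to give 58% in this assay, with a range from 40% to 75%.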

Compound 4, a percentage reported as inhibition, at one concentration (the size of the read-out at that concentration, not a potency): 66.7%
Estimate against measurement, compound 4: 8.7 percentage points below, and the stated range covers the measured number.
By their numbers in this assay, from the lowest: compounds 2, 1, 3 and 4 (each within the scatter of the next).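

In this assay, for the compounds shown here, the exchange of 2-chlorophenyl for 2,3-dimethylphenyl on an amine nitrogen in a ring gives the first step that can be read between two compounds differing in one place, a number 6.6 percentage points higher from compound 1 to compound 4 (within the scatter). At this position, then, a carbon-only aromatic ring carrying two methyl groups and no chlorine keeps the inhibition at the one concentration tested within the scatter of the chlorinated group, so this single step does not tell the two groups apart. Nothing in the data shown bears on what lies behind this result.

The compounds shown leave open whether the two methyl groups count singly, which 2-methylphenyl or 3-methylphenyl at the same place would address, and whether the place accepts a ring other than a carbon-only aromatic one, such as pyridyl or cyclohexyl. They also leave open whether the two groups would still read alike as full potency values rather than at a single concentration, or with a propyl chain in place of the ethyl chain that compound 1 and compound 4 share.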